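A Short Chain Change on a Glycine-Linked Nucleoside Analogue

The source may hold more compounds than are shown below. What is called first, only, known or untested is meant among the compounds shown, and "the series" means these compounds.

Compound 1 `CC(C)CCCCCCCCCCCCC(=O)NCC(=O)N[C@@H]1[C@@H](O)[C@H](O)[C@@H](Nc2ncnc3[nH]cnc23)O[C@H]1C` carries a long branched acyl chain joined through a glycine unit to the shared core, and in a functional assay on L1210 cells (Mus musculus) for inhibition, read by thymidine incorporation, with a stated time of 3 h (on this read-out higher numbers stand for an effect only at larger amounts of compound and lower numbers for an effect already at smaller amounts), compound 1 gives 1.8 uM. Compound 2 `CC(C)CCCCCCCCCCCCC(=O)N[C@@H]1[C@@H](O)[C@H](O)[C@@H](Nc2ncnc3[nH]cnc23)O[C@H]1C` lacks the glycine unit; in this assay compound 2 reaches only the limit > 1000 uM. Compound 3 `CCOCCC(=O)NCC(=O)N[C@@H]1[C@@H](O)[C@H](O)[C@@H](Nc2ncnc3[nH]cnc23)O[C@H]1C` keeps the glycine unit but carries a short ethoxy-capped chain; in this assay compound 3 likewise reaches only the limit > 1000 uM. Two of the three values stand at the limit of > 1000 uM in this assay, at which 2 of the 3 values shown sit. Compound 4 `CCCCCC(=O)NCC(=O)N[C@@H]1[C@@H](O)[C@H](O)[C@@H](Nc2ncnc3[nH]cnc23)O[C@H]1C` is not yet measured and differs from compound 3 by propyl in place of ethoxy on a saturated chain carbon, two bonds along the chain from a carbonyl carbon. With the chain still short, compound 4 is expected to show a step of a number no higher from compound 3 to compound 4 (the limit leaves the size open) of no size beyond the scatter. Compound 4 is estimated at 1000 uM, within 100 uM to 3000 uM.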

Compound 4, concentration for half-maximal effect: > 1000 uM
Compound 4 gave a limit, no number; the forecaster's own chance of this, stated with the estimate: 80%; the middle value lies on the limit itself.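

In this assay, compound 3 and compound 4 both give a limit rather than a number, so the step between them cannot be read, and an all-carbon propyl in place of ethoxy brings no measurable value here. Hydrogen in place of 8-methylnonyl, five bonds along the chain from a carbonyl carbon, gives an at least 550-fold higher number from compound 1 to compound 4 (2.74 log units; beyond the scatter). The series now clusters at one ceiling: the limit of > 1000 uM in this assay, at which 3 of the 4 values shown sit.

Still open, as far as these compounds go, is whether a mid-length chain such as octyl would give a readable number. Also open, from the compounds shown here alone, is what an amine at the chain end would do.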